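Replacing the fluorophenoxy arm with a methyl-isoxazole

The source may hold more compounds than are shown below. What is called first, only, known or untested is meant among the compounds shown, and "the series" means these compounds.

Among the measured compounds shown here, compound 1 `C[C@@H]1CN(Cc2ccc(-c3ccccc3CN(C)C(=O)COc3ccc(F)cc3)cc2)C[C@H](C)N1` gives the highest of the two numbers measured so far: in a functional assay on HEK293 cells for agonist activity at Motilin receptor (Homo sapiens), read by FLIPR (a higher number here means that more compound is needed for the effect, a lower number that less compound is needed), compound 1 gives 31.6 nM, while compound 2 `C[C@@H]1CN(Cc2ccc(-c3ccccc3CN(C)C(=O)CSc3ccccc3)cc2)C[C@H](C)N1` gives 3.16 nM. The change to compound 3 `Cc1cc(CC(=O)N(C)Cc2ccccc2-c2ccc(CN3C[C@@H](C)N[C@@H](C)C3)cc2)on1` is 3-methyl-1,2-oxazol-5-yl in place of 4-fluorophenoxy on a saturated chain carbon bound to a carbonyl carbon. For the measured compounds named here, only one measured step touches the same place, a 10-fold lower number from compound 1 to compound 2 (1.00 log units; beyond the scatter), but it swaps in a different group, so it offers no direct guide. The step of a 1.1-fold lower number from compound 1 to compound 3 (0.02 log units; within the scatter) is therefore expected to stay near compound 1 rather than point clearly either way. Compound 3 is estimated at 30 nM, within 6 nM to 150 nM.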

Compound 3, half-maximal effective concentration: 1000 nM
Compound 3: the middle estimate sits 33-fold (1.52 log units) below what was measured, and the stated range ends below it.
By their numbers in this assay, from the lowest: compound 2; then compound 1; then compound 3.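

In this assay, the place on a saturated chain carbon bound to a carbonyl carbon proves sensitive to the aromatic arm it carries: 3-methyl-1,2-oxazol-5-yl brings a 32-fold higher number from compound 1 to compound 3 (1.50 log units; beyond the scatter) and, set against phenylsulfanyl, a 320-fold higher number from compound 2 to compound 3 (2.50 log units; beyond the scatter), both large steps. Among these three compounds, the only five-membered aromatic ring with 2 hetero atoms comes with the highest number, though three compounds establish no general pattern. Nothing available accounts for this result.

As far as these compounds go, the ring, its methyl and its direct attachment to the chain all change together, so their separate contributions remain open. An unsubstituted phenoxy or a pyridyl ring at this place would test how far the step depends on the ring itself.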